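This account rests on a few compounds, and the source may have more. Where it says the series, first, only, none or still open, it means among the compounds named here.

Of the compounds shown here, three sharing one core have been tested in an ADME assay on RAW264.7 cells (Mus musculus) for cytotoxicity, read by MTT assay, with a stated time of 24 h; a higher number here means that more compound is tolerated, a lower number that less compound is tolerated. Compound 1 `Cc1ccc(C2=NN(C3=NC(=O)CS3)C(c3ccc(F)cc3)C2)cc1C` gives 246000 nM. Compound 2 `Cc1cccc(C2CC(c3ccc(C)c(C)c3)=NN2C2=NC(=O)CS2)c1` gives 237000 nM, and compound 3 `O=C1CSC(N2N=C(c3ccc(Cl)c(Cl)c3)CC2c2ccc(F)cc2)=N1` gives 139000 nM; the step of a 1.8-fold lower number from compound 1 to compound 3 (0.25 log units; within the scatter) corresponds to the difference (3,4-dichlorophenyl in place of 3,4-dimethylphenyl on a carbon with a double bond to nitrogen). The change 3-methylphenyl in place of 4-fluorophenyl on a saturated ring carbon produced the step of a 1.0-fold lower number from compound 1 to compound 2 (0.02 log units; within the scatter).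

Compound 4 `Cc1cccc(C2CC(c3ccc(Cl)c(Cl)c3)=NN2C2=NC(=O)CS2)c1` is not yet measured. It arises from compound 3 by 3-methylphenyl in place of 4-fluorophenyl on a saturated ring carbon, the same kind of change as from compound 1 to compound 2, though here the ring atom two bonds away bears a 3,4-dichlorophenyl group rather than a 3,4-dimethylphenyl group. Because the step of a 1.0-fold lower number from compound 1 to compound 2 (0.02 log units; within the scatter) was within the scatter, a step of about a 1.0-fold lower number from compound 3 to compound 4 (0.01 log units; within the scatter) is expected for compound 4 in this assay. Compound 4 is therefore estimated at 135000 nM, between 70000 nM and 270000 nM.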

Compound 4, half-maximal cytotoxic concentration: 204000 nM
Compound 4: the middle estimate sits 1.5-fold (0.18 log units) below what was measured, within the range that was stated.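

In this assay, 3-methylphenyl in place of 4-fluorophenyl gives a 1.5-fold higher number from compound 3 to compound 4 (0.17 log units; within the scatter), and 3,4-dichlorophenyl in place of 3,4-dimethylphenyl gives a 1.2-fold lower number from compound 2 to compound 4 (0.07 log units; within the scatter). Set beside its earlier counterpart, the first change shows no gap beyond the scatter: the same change on two cores in this assay, a 1.0-fold lower number (0.02 log units; within the scatter) from compound 1 to compound 2 and a 1.5-fold higher number (0.17 log units; within the scatter) from compound 3 to compound 4, 1.5-fold (0.18 log units) apart, within the scatter of two such steps. The second change shows none either, yet every step involved lies within the scatter, so the two cores agree only in that neither change moves this read-out beyond that scatter, and this does not show that a change of real size would carry over: the same change on two cores in this assay, a 1.8-fold lower number (0.25 log units; within the scatter) from compound 1 to compound 3 and a 1.2-fold lower number (0.07 log units; within the scatter) from compound 2 to compound 4, 1.5-fold (0.18 log units) apart, within the scatter of two such steps.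

The compounds shown carry only substituted phenyl groups at these two places. They leave open whether an amine, a carboxylic acid or a longer alkyl chain there would give a step beyond the scatter, and whether such a step would carry from one core to the other.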